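Anilide series: 2-chlorophenyl in place of 3-nitrophenyl

The source may report more compounds than this note shows. Statements on the series, on what has been measured and on what is new or still open speak of the compounds shown alone.

Working notes on three aryl amides that share one core. Compound 1 `Nc1ccccc1NC(=O)CCCNCC(=O)Nc1ccc(Br)cc1` carries a 4-bromophenyl on the amide-type nitrogen. In a functional assay on U-251 cells (Homo sapiens) for inhibition, read by MTT assay, with a stated time of 2 days (a lower number here means that less compound is tolerated, a higher number that more compound is tolerated), compound 1 gives > 100000 nM, which is a limit of the assay and not a number. Compound 2 `Nc1ccccc1NC(=O)CCCNCC(=O)Nc1cccc([N+](=O)[O-])c1` carries a 3-nitrophenyl in place of the 4-bromophenyl. In this assay compound 2 gives > 100000 nM, again a limit and not a number. Within the data shown here, compound 2 therefore stands at the limit of > 100000 nM in this assay, at which 2 of the 2 values shown sit, the same place as the only other measured member, and the step that the two limits leave unreadable from compound 1 to compound 2 cannot be read from the two results.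

Compound 3 `Nc1ccccc1NC(=O)CCCNCC(=O)Nc1ccccc1Cl` is the next member: 2-chlorophenyl in place of 3-nitrophenyl on an amide-type nitrogen. Among the measured compounds shown here, the single measured step bears on this change only in that it is unreadable, since both results stop at the limit. No step beyond the scatter is therefore expected in this assay, in either direction, and the most likely outcome is a further limit. The estimated step of a number no higher from compound 2 to compound 3 (the limit leaves the size open) is taken as none. Compound 3 is expected to give about 100000 nM, between 30000 nM and 300000 nM, in this assay.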

Compound 3, concentration lethal to 50% of the cells: > 100000 nM
Compound 3 was reported as a limit; the forecaster's own chance of this, stated with the estimate: 80%; the middle value sits exactly at the limit.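

In this assay compound 3 gives > 100000 nM, a limit of the assay and not a number. No new step can be read among compound 1, compound 2 and compound 3, and all three results stop at the same point: the limit of > 100000 nM in this assay, at which 3 of the 3 values shown sit. The compounds shown leave open whether the 4-bromophenyl, 3-nitrophenyl and 2-chlorophenyl groups differ at all in this assay.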